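The compounds below may be only part of what the source reports. "The series", "measured", "known", "first", "only" and "open" are said of these compounds alone.

In an ADME assay on BHK-21 cells (Mesocricetus auratus) for cytotoxicity, read by MTT assay, with a stated time of 72 h (on this read-out higher numbers stand for lower toxicity in this test and lower numbers for higher toxicity in this test), compound 1 (`Cc1ccccc1C1CC(c2ccc(OCc3ccccc3)cc2)=NN1c1ccc(S(N)(=O)=O)cc1`) gives 20000 nM and sits in the middle of the three measured values. Compound 2 (`NS(=O)(=O)c1ccc(N2N=C(c3ccc(OCc4ccccc4)cc3)CC2c2ccccc2)cc1`) gives 80000 nM at the top and compound 3 (`Cc1cccc(C2CC(c3ccc(OCc4ccccc4)cc3)=NN2c2ccc(S(N)(=O)=O)cc2)c1`) gives 8000 nM at the bottom.

The next change leads to compound 4 (`Cc1ccccc1C1CC(c2ccccc2)=NN1c1ccc(S(N)(=O)=O)cc1`) and is hydrogen in place of benzyloxy on an aromatic carbon, para to a large group (hydrogen in place of benzyloxy on an aromatic carbon).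

Among the compounds with values here, all three measured compounds keep the benzyloxy, so no measured step tests its loss. The steps available concern only the methyl: its removal (a 4.0-fold higher number from compound 1 to compound 2 (0.60 log units; beyond the scatter)), its shift from 2-methylphenyl to 3-methylphenyl (a 2.5-fold lower number from compound 1 to compound 3 (0.40 log units; beyond the scatter)) and its addition (a 10-fold lower number from compound 2 to compound 3 (1.00 log units; beyond the scatter)). They show only how far the numbers move in this small set, and all three are modest but beyond the scatter.

A step of similar size is therefore expected in this assay, with the data leaving the direction open. A slight lean towards a higher number rests thinly on compound 2 (80000 nM), which lacks the methyl. The expected move is a 1.8-fold higher number from compound 1 to compound 4 (0.24 log units; within the scatter) and this estimate is weak. Compound 4 is expected at 35000 nM within an estimated range of 8000 nM to 150000 nM in this read-out.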

Compound 4, half-maximal cytotoxic concentration: 14000 nM
Beside the measured number, compound 4's estimate is 2.5-fold (0.40 log units) above it; low and high end bracket the measured number.
By their numbers in this assay, from the lowest: compounds 3, 4 and 1 (each within the scatter of the next, the first and the last beyond it); then compound 2.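

In this assay, replacing the benzyloxy, with its 8 heavy atoms and its six-membered aromatic ring of carbon only, by hydrogen on an aromatic carbon, para to a large group, gives a 1.4-fold lower number from compound 1 to compound 4 (0.15 log units; within the scatter), so this read-out does not separate compound 1 from compound 4. The earlier steps shown here all concerned the methyl and all lay beyond the scatter, whereas this first step at a second place lies within it, and the whole benzyloxy can go without a change that this test can resolve. No measurement at hand offers an explanation for this result.

Open, from the compounds shown here alone, is whether an amine or a carboxylic acid in place of the benzyloxy would also stay within the scatter of compound 1 in this assay, as hydrogen does here. Also open is whether the methyl steps seen with the benzyloxy present, such as a 4.0-fold higher number from compound 1 to compound 2 (0.60 log units; beyond the scatter), hold when hydrogen stands at this place, as compound 4 is the only compound shown with hydrogen there.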